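From One Hydroxylated Ring to Another on the Carbonyl

The compounds below may be only part of what the source reports. "The series", "measured", "known", "first", "only" and "open" are said of these compounds alone.

In an assay on isolated protein for inhibition of mitogen-activated protein kinase kinase kinase 14 (Homo sapiens), read by ADP-Glo, with a stated time of 60 min, tested at 100 uM, in the presence of a further agent that is not named here (on this read-out higher numbers stand for more inhibition at the one concentration tested (going by the name of the read-out) and lower numbers for less inhibition), three related amides have been measured. Compound 1 `O=C(Nc1cc(C(F)(F)F)cc(C(F)(F)F)c1)c1nsnc1O` gives 4.34%. Compound 2 `O=C(Nc1cc(C(F)(F)F)cc(C(F)(F)F)c1)c1nonc1O` gives 19.3%, and the step of a number 15 percentage points higher from compound 1 to compound 2 (beyond the scatter) is the larger of the two steps seen. Compound 3 `O=C(Nc1cccc(C(F)(F)F)c1)c1nsnc1O` gives -1.1%, and the step of a number 5.4 percentage points lower from compound 1 to compound 3 (within the scatter) shows that losing one trifluoromethyl changed little. Compound 2 therefore stands highest of the three numbers, beyond the scatter against both others.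

Compound 4 `Cn1nc(O)c(C(=O)Nc2cc(C(F)(F)F)cc(C(F)(F)F)c2)n1` has not yet been measured. Its change from compound 2 is 5-hydroxy-2-methyl-2H-1,2,3-triazol-4-yl in place of 4-hydroxy-1,2,5-oxadiazol-3-yl on a carbonyl carbon. For the measured compounds named here, only one measured step touches the ring on the carbonyl carbon, the step of a number 15 percentage points higher from compound 1 to compound 2 (beyond the scatter), and it moved the read-out by a modest amount. Going by the values given here, no measured compound carries a 5-hydroxy-2-methyl-2H-1,2,3-triazol-4-yl, so the direction of this new exchange cannot be read from the data; a move of similar size either way, or none beyond the scatter, is all plausible. Compound 4 is therefore expected to give 15%. For compound 4 the estimated range runs from -5% to 35%. The expected step of a number 4.3 percentage points lower from compound 2 to compound 4 (within the scatter) stays within the scatter.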

Compound 4, a percentage reported as inhibition, at one concentration (the size of the read-out at that concentration, not a potency): 9.1%
Compound 4: the middle estimate sits 5.9 percentage points above what was measured, within the range that was stated.
By their numbers in this assay, from the lowest: compounds 3, 1 and 4 (each within the scatter of the next, the first and the last beyond it); then compound 2.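

In this assay, a second exchange of the ring on the carbonyl carbon also shifts the number: the step of a number 10.2 percentage points lower from compound 2 to compound 4 (beyond the scatter) is modest but beyond the scatter. The step of a number 4.8 percentage points higher from compound 1 to compound 4 (within the scatter) lies within the scatter, so the 5-hydroxy-2-methyl-2H-1,2,3-triazol-4-yl ring and the sulfur-containing ring of the shared amide cannot be told apart here, and the 4-hydroxy-1,2,5-oxadiazol-3-yl ring alone stands clear of both. This position therefore responds to the identity of the ring, though only by small amounts at the one concentration tested, and nothing available gives a reason for the difference between these rings.

The compounds shown leave open whether the methyl on the triazole ring matters, since the exchange to compound 4 changes the ring and adds that methyl together, and a triazole with hydrogen in its place would separate the two. They also leave open whether the hydroxy group on the ring matters, which an amino group in its place would test, and whether removing one trifluoromethyl would cost anything with the 4-hydroxy-1,2,5-oxadiazol-3-yl ring on the carbonyl carbon.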